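Swapping a Pyrimidine for a Carbamate on a Fused Core

The source may report more compounds than this note shows. Statements on the series, on what has been measured and on what is new or still open speak of the compounds shown alone.

Measured so far:
compound 1 `O=C(NC1(c2ccc3c(n2)CCN3c2ccnc(C(F)(F)F)n2)CCC1)c1ccc(Cl)cc1` gives 93 nM
compound 2 `O=C(OC1CC1)N1CCc2nc(C3(C(=O)Nc4ccc(F)cc4)CCC3)ccc21` gives 2.7 nM

Both numbers come from an assay on HeLa cells for inhibition of Indoleamine 2,3-dioxygenase 1 (Homo sapiens); a higher number here means a weaker inhibitor, a lower number a stronger inhibitor. Going by the values given here, compound 1 stands at the higher of the two values, the weaker inhibitor; compound 2 lies well beyond the usual scatter from it, so the gap between them is real, but the two differ in more than one place and no single step links them.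

Compound 3 `O=C(NC1(c2ccc3c(n2)CCN3C(=O)OC2CC2)CCC1)c1ccc(Cl)cc1` is the untested partner of compound 1. The change is cyclopropyloxycarbonyl in place of 2-(trifluoromethyl)pyrimidin-4-yl on a nitrogen on an aromatic ring in a ring. Everything else in compound 1, including the chlorophenyl amide and the fused core, is kept.

Because compound 2, which carries the same cyclopropyloxycarbonyl group on the same nitrogen, gives 2.7 nM, the expectation is that this group is compatible with strong inhibition, and a move toward lower values is anticipated. The step from compound 1 to compound 3 is expected to be a 12-fold lower number from compound 1 to compound 3 (1.07 log units; beyond the scatter), clearly beyond the scatter, with compound 3 estimated at 8 nM within a range from 2 nM to 30 nM.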

Compound 3, half-maximal inhibitory concentration: 4.5 nM
For compound 3 the middle estimate is 1.8-fold (0.25 log units) above the measured one; low and high end bracket the measured number.
By their numbers in this assay, from the lowest: compounds 2 and 3 (each within the scatter of the next); then compound 1.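

Going by these compounds alone, this is the first pair that differs in only one place, and in this assay it shows that the group on this nitrogen of the five-membered non-aromatic ring strongly affects inhibition: the swap gives a 21-fold lower number from compound 1 to compound 3 (1.32 log units; beyond the scatter), with the chlorophenyl amide and the rest of the core unchanged. For this pair, an aromatic pyrimidine on that nitrogen is not needed for a low number, as the cyclopropyloxycarbonyl group has fewer heavy atoms and a three-membered non-aromatic ring in place of the six-membered aromatic one, while the counts of hydrogen-bond donors and acceptors are the same in both groups. Within the data shown here, nothing available explains why this swap moves the number so far.

The change alters several features at once, so the pair cannot show whether the carbonyl, the oxygen link, the cyclopropyl ring or the loss of the trifluoromethylpyrimidine accounts for the step. Going by these compounds, how an ethoxycarbonyl group, a plain acetyl group or an unsubstituted pyrimidin-4-yl would behave on this nitrogen remains open, and any of these could help separate those features.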